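The source may hold more compounds than are shown below. What is called first, only, known or untested is meant among the compounds shown, and "the series" means these compounds.

Measured compounds:
- Compound 1 `COc1ccccc1/C=C1/SC(N2CCC[C@H]2C(=O)Nc2ccc3ncnc(Nc4cccc(Cl)c4)c3c2)=NC1=O` gives 22100 nM in a functional assay on HepG2 cells (Homo sapiens) for antiproliferative activity, read by MTT assay; a higher number here means a weaker inhibitor, a lower number a stronger inhibitor.
- Compound 2 `O=C1N=C(N2CCC[C@H]2C(=O)Nc2ccc3ncnc(Nc4cccc(Cl)c4)c3c2)S/C1=C/c1ccc(-c2ccccc2)cc1` gives 15400 nM in this assay.
- Compound 3 `O=C1N=C(N2CCC[C@H]2C(=O)Nc2ccc3ncnc(Nc4cccc(Cl)c4)c3c2)S/C1=C/c1ccc2ccccc2n1` gives 22900 nM in this assay.

Compound 1 has the second highest of the three numbers, yet all three lie within the scatter of one another: the nearest is compound 3, with a 1.0-fold higher number from compound 1 to compound 3 (0.02 log units; within the scatter), and the furthest is compound 2, with a 1.4-fold lower number from compound 1 to compound 2 (0.16 log units; within the scatter). The remaining pair shows a 1.5-fold higher number from compound 2 to compound 3 (0.17 log units; within the scatter).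

Compound 4 `O=C1N=C(N2CCC[C@H]2C(=O)Nc2ccc3ncnc(Nc4cccc(Cl)c4)c3c2)S/C1=C/c1ccccc1Cl` differs from compound 1 in one place: chloro in place of methoxy on an aromatic carbon. The ring carrying this group is the one that was exchanged in every measured step. Among the compounds with values here, none of those steps swaps methoxy for chloro, so no direct precedent exists; what they do show is that replacing the whole aromatic group, even by a much larger quinolin-2-yl or 4-phenylphenyl, left the number within the scatter each time. A smaller change at the same place is therefore expected to do no more. The expected step is a 1.1-fold lower number from compound 1 to compound 4 (0.04 log units; within the scatter). Compound 4 is estimated to give 20000 nM, with a range from 8000 nM to 50000 nM.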

Compound 4, half-maximal inhibitory concentration: 28100 nM
Beside the measured number, compound 4's estimate is 1.4-fold (0.15 log units) below it, within the range that was stated.
By their numbers in this assay, from the lowest: compounds 2, 1, 3 and 4 (each within the scatter of the next).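

In this assay, exchanging a single substituent on an aromatic carbon, ortho to a large group, gives a 1.3-fold higher number from compound 1 to compound 4 (0.10 log units; within the scatter) and so leaves the number as close to that of compound 1 as the exchanges of the whole aromatic group did. The 2-chlorophenyl group also stands within the scatter of the larger groups, with a 1.2-fold higher number from compound 3 to compound 4 (0.09 log units; within the scatter) and a 1.8-fold higher number from compound 2 to compound 4 (0.26 log units; within the scatter) as the two steps, so all four compounds read alike at this position and neither methoxy nor chloro separates from the others. No measurement is available that could explain this result.

Going by these compounds, whether an amine or a carboxylic acid on this same aromatic carbon would also stay within the scatter remains open. The compounds shown vary only this aromatic group, so they say nothing about changes to the shared core.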